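Series notes: (furan-2-yl)methyl to 2-hydroxy-3-methoxybenzyl amine

The source may report more compounds than this note shows. Statements on the series, on what has been measured and on what is new or still open speak of the compounds shown alone.

Of the compounds shown here, two have been measured. Compound 1 `COc1cccc(CNCCCNc2ccnc3cc(Oc4ccccc4)ccc23)c1O` in a physicochemical assay for solubility, with a stated time of 18 h, at pH 7.4 (on this read-out lower numbers stand for lower solubility and higher numbers for higher solubility), gives 14500 nM. Compound 2 `c1coc(CNCCCNc2ccnc3cc(-c4cccc5ccccc45)ccc23)c1` in this assay gives 32000 nM, the higher of the two numbers, and its gap to compound 1 lies beyond the usual scatter. Compound 3 `COc1cccc(CNCCCNc2ccnc3cc(-c4cccc5ccccc45)ccc23)c1O` differs from compound 2 in one place: 2-hydroxy-3-methoxyphenyl in place of furan-2-yl on a saturated chain carbon bound to an amine nitrogen. For the measured compounds named here, no measured pair covers this change directly. Compound 1 carries the same 2-hydroxy-3-methoxybenzyl group and gives 14500 nM, so a modest decrease is expected, a 1.6-fold lower number from compound 2 to compound 3 (0.20 log units; within the scatter). Compound 3 is estimated in this assay at 20000 nM, within 7000 nM to 55000 nM.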

Compound 3, solubility: 32000 nM
The estimate for compound 3 lay 1.6-fold (0.20 log units) below the measured number; the measured number falls inside the stated range.
By their numbers in this assay, from the lowest: compound 1; then compounds 2 and 3 (each within the scatter of the next).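

In this assay 2-hydroxy-3-methoxyphenyl in place of furan-2-yl on a saturated chain carbon bound to an amine nitrogen gives no change at the digits printed from compound 2 to compound 3 (within the scatter) with naphthalen-1-yl held in the shared core, so on this background the exchange leaves the read-out where it was. For the compounds shown here, with the 2-hydroxy-3-methoxybenzyl amine held constant, naphthalen-1-yl in place of phenoxy on an aromatic carbon gives a 2.2-fold higher number from compound 1 to compound 3 (0.34 log units; beyond the scatter) as the first single-place step at that site.

Open, from the compounds shown here alone, is whether a pyridine or a carboxylic acid in place of 2-hydroxy-3-methoxyphenyl would shift the number beyond the scatter. Nothing at hand bears on a cause for either step.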